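This account rests on a few compounds, and the source may have more. Where it says the series, first, only, none or still open, it means among the compounds named here.

Compound 1 `CCCSC[C@H](NC(C)=O)C(=O)CCl` and compound 2 `CCCCCCCSC[C@H](NC(C)=O)C(=O)CCl` share one core and differ only in the length of the chain on the sulfur. In a functional assay on NALM-6 cells (Homo sapiens) (a higher number here means a weaker inhibitor, a lower number a stronger inhibitor), compound 1 gives 6900 nM and compound 2 gives 4800 nM, which is a 1.4-fold lower number from compound 1 to compound 2 (0.16 log units; within the scatter). Compound 2 therefore has the smaller of the two numbers, though its gap to compound 1 lies within the scatter. Compound 3 `CCCCCCCCCCCCCSC[C@H](NC(C)=O)C(=O)CCl` lengthens the chain again: hexyl in place of hydrogen on a saturated chain carbon, seven bonds along the chain from a sulfur. Among the measured compounds shown here, the only step that bears on this, a 1.4-fold lower number from compound 1 to compound 2 (0.16 log units; within the scatter), stayed within the scatter, so the expected step of a 1.2-fold lower number from compound 2 to compound 3 (0.08 log units; within the scatter) is small or none beyond the scatter. For compound 3 the estimated value is 4000 nM, ranging from 1500 nM to 10000 nM.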

Compound 3, half-maximal inhibitory concentration: > 100000 nM
Compound 3: a limit, no number; the forecaster's own chance of this, stated with the estimate: 5%; middle value at least 25-fold (1.39 log units) from the limit.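

Adding hexyl at this place, seven bonds along the chain from a sulfur, has a large effect in this assay: an at least 20-fold higher number from compound 2 to compound 3 (1.31 log units; beyond the scatter). Among the compounds shown here, the earlier butyl step stayed within the scatter, so this is the first sign that chain length on the sulfur can matter here, and that lengthening it does not keep giving the same result. The value for compound 3 is a limit and not a number: the limit of > 100000 nM in this assay, at which 1 of the 3 values shown sits.

Where along the chain the sharp change sets in remains open, for example whether a decyl chain on the sulfur would behave like compound 2 or like compound 3. Also open, going by these compounds, is whether a long chain ending in a carboxylic acid or an amine would follow the same course.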